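This account rests on a few compounds, and the source may have more. Where it says the series, first, only, none or still open, it means among the compounds named here.

Working notes on the urea series. Compound 1 `O=C(Nc1cccc(-n2cc(-c3ccncc3)c(-c3cc(O)cc(Cl)c3)n2)c1)Nc1ccc(Cl)c(C(F)(F)F)c1`, compound 2 `COc1cc(Cl)cc(-c2nn(-c3cccc(NC(=O)Nc4ccc(Cl)c(C(F)(F)F)c4)c3)cc2-c2ccncc2)c1` and compound 3 `COc1cc(Cl)cc(-c2nn(-c3cccc(NC(=O)Nc4cc(C(F)(F)F)cc(C(F)(F)F)c4)c3)cc2-c2ccncc2)c1` have been run in a functional assay on DU-145 cells (Homo sapiens) for inhibition, read by sulforhodamine B assay, with a stated time of 48 h, tested at 10 uM; on this read-out lower numbers stand for a stronger effect and higher numbers for a weaker effect at the one concentration tested; compound 4 `COc1cc(Cl)cc(-c2nn(-c3cccc(NC(=O)c4cccc(C(F)(F)F)c4)c3)cc2-c2ccncc2)c1` has not. In this assay compound 1 gives 18.7%, compound 2 gives 15.2% and compound 3 gives 13.1%. Compound 2 thus stands second highest of the three numbers, with compound 3 nearest and compound 1 furthest, both within the scatter of it. Among the compounds with values here, the one step between measured compounds is a number 3.5 percentage points lower from compound 1 to compound 2 (within the scatter), which concerns the oxygen substituent and not the part changed here. The change from compound 2 to compound 4 is 3-(trifluoromethyl)phenyl in place of (4-chloro-3-(trifluoromethyl)phenyl)amino on a carbonyl carbon. Within the data shown here, no measured step of this kind exists; the values of compound 2 and compound 3 show only that two different aryl groups on the urea give numbers within the scatter of each other. The step of a number 14.8 percentage points higher from compound 2 to compound 4 (beyond the scatter) is therefore expected with low confidence, and a wide range is set. For compound 4 in this assay the estimate is 30%, between 12% and 60%.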

Compound 4, a percentage reported as activity, at one concentration (the size of the read-out at that concentration, not a potency): 83.8%
Compound 4: middle estimate off by 53.8 percentage points, on the low side, outside the stated range (above it).
By their numbers in this assay, from the lowest: compounds 3, 2 and 1 (each within the scatter of the next); then compound 4.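

Working notes, urea series: in this assay the carbonyl carbon whose other neighbour is an amide-type nitrogen proves to be a place where a change can matter, with 3-(trifluoromethyl)phenyl in place of (4-chloro-3-(trifluoromethyl)phenyl)amino giving a number 68.6 percentage points higher from compound 2 to compound 4 (beyond the scatter). Compounds 1, 2 and 3 all keep the urea and lie within the scatter of each other, so only compound 4 shows that the read-out can move this far within the series. The change takes away the amino nitrogen with its hydrogen-bond donor and the chlorine together, and no measurement at hand bears on the reason for the step.

Going by these compounds, what stays open is whether the step follows the nitrogen or the chlorine, which (3-(trifluoromethyl)phenyl)amino on the same carbonyl carbon would separate. Also open, on these data alone, is how a methylene or an ether oxygen in place of the amino nitrogen would read.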